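Phenyl on the aromatic nitrogen of compound 3

The compounds below may be only part of what the source reports. "The series", "measured", "known", "first", "only" and "open" are said of these compounds alone.

Values so far in a physicochemical assay, read by spectrophotometry; on this read-out lower numbers stand for stronger inhibition and higher numbers for weaker inhibition
compound 1 `COc1ccc(-n2nc(/C=C/c3ccc(N(C)C)cc3)cc2/C=C/c2ccc(N(C)C)cc2)cc1` gives 88.1 ug/mL
compound 2 `CN(C)c1ccc(/C=C/c2cc(/C=C/c3ccc(N(C)C)cc3)n(-c3ccc(F)cc3)n2)cc1` gives 74.4 ug/mL
compound 3 `CN(C)c1ccc(/C=C/c2cc(/C=C/c3ccc(N(C)C)cc3)[nH]n2)cc1` gives 46.1 ug/mL
compound 4 `CN(C)c1ccc(/C=C/c2cc(/C=C/c3ccc(N(C)C)cc3)n(-c3ccccc3)n2)cc1` is not yet measured

Compound 3 gives 46.1 ug/mL and sits within the scatter of both other measured compounds, so no order among the three can be read. The change to compound 4 is phenyl in place of hydrogen on an aromatic nitrogen on an aromatic nitrogen. Going by the values given here, two measured steps bear on it, both running the opposite way, with hydrogen replacing 4-methoxyphenyl or 4-fluorophenyl: a 1.9-fold lower number from compound 1 to compound 3 (0.28 log units; within the scatter) and a 1.6-fold lower number from compound 2 to compound 3 (0.21 log units; within the scatter) are both small. Fluoro in place of methoxy gave a 1.2-fold lower number from compound 1 to compound 2 (0.07 log units; within the scatter) and likewise does not separate the two compounds that carry a substituted phenyl. Read in reverse, these steps point to a slightly higher number in this assay for compound 4, but no step beyond the scatter is expected. The estimated step is a 1.7-fold higher number from compound 3 to compound 4 (0.23 log units; within the scatter) on this reading. For compound 4 the estimated value is 78 ug/mL with an expected range of 45 ug/mL to 135 ug/mL for now.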

Compound 4, half-maximal inhibitory concentration: 74 ug/mL
Beside the measured number, compound 4's estimate is 1.1-fold (0.02 log units) above it; low and high end bracket the measured number.
By their numbers in this assay, from the lowest: compounds 3, 4, 2 and 1 (each within the scatter of the next).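

In this assay, a 1.6-fold higher number from compound 3 to compound 4 (0.21 log units; within the scatter) for phenyl in place of hydrogen shows that the unsubstituted ring on the aromatic nitrogen, like the substituted rings, does not separate from hydrogen at this position. With a 1.0-fold lower number from compound 2 to compound 4 (0.00 log units; within the scatter) for hydrogen in place of fluoro and a 1.2-fold lower number from compound 1 to compound 4 (0.08 log units; within the scatter) for hydrogen in place of methoxy, neither substituent on that phenyl separates from the unsubstituted ring, so all steps at this position in the four compounds stay within the scatter. No measurement at hand offers an explanation for these small steps.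

Open, from the compounds shown here alone, is whether any group on this nitrogen gives a step beyond the scatter. An amine or a carboxylic acid on the phenyl, or a longer chain in its place, lies outside the compounds shown.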